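Methoxy Additions and Cytotoxicity Across Three Measured Compounds

This account rests on a few compounds, and the source may have more. Where it says the series, first, only, none or still open, it means among the compounds named here.

In an ADME assay on K562 cells (Homo sapiens) for cytotoxicity, with a stated time of 72 h (on this read-out higher numbers stand for weaker inhibition and lower numbers for stronger inhibition), the measured compounds are:
compound 1, `COc1ccccc1CNc1ncnc2c1ncn2C1CCCCO1`, with 97000 nM;
compound 2, `COc1cccc(OC)c1CNc1ncnc2c1ncn2C1CCCCO1`, with 10300 nM;
compound 3, `COc1ccc(CNc2ncnc3c2ncn3C2CCCCO2)cc1OC`, which gives only a limit, > 100000 nM.

Compound 1 and compound 2 differ by methoxy in place of hydrogen on an aromatic carbon, and that change gave a 9.4-fold lower number from compound 1 to compound 2 (0.97 log units; beyond the scatter). Compound 4, `COc1cc(OC)c(OC)cc1CNc1ncnc2c1ncn2C1CCCCO1`, is not yet measured; it differs from compound 3 by methoxy in place of hydrogen on an aromatic carbon, the same kind of change, though here the place is also para to a methoxy group. How the core of compound 3 differs from that of compound 1 is not broken down here, and compound 3 sits at the limit (the limit of > 100000 nM in this assay, at which 1 of the 3 values shown sits). In this assay compound 4 is expected to give 40000 nM, between 8000 nM and 200000 nM, resting on the earlier step. That would correspond to an expected at least 2.5-fold lower number from compound 3 to compound 4 (0.39 log units; beyond the scatter).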

Compound 4, half-maximal inhibitory concentration: > 100000 nM
Compound 4 ended at the assay's limit; the forecaster's own chance of this, stated with the estimate: 40%; at least 2.5-fold (0.39 log units) between middle value and limit.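

In this assay, compound 3 and compound 4 both stand at a limit rather than at a number, so no step between them can be read: the limit of > 100000 nM in this assay, at which 2 of the 4 values shown sit.

On these data alone, whether the added methoxy of compound 4 changes cytotoxicity relative to compound 3 remains open.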